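This account rests on a few compounds, and the source may have more. Where it says the series, first, only, none or still open, it means among the compounds named here.

Going by the values given here, in an ADME assay on the whole organism (Rattus norvegicus, strain Sprague-Dawley) for pharmacokinetics, read by LC-MS, with a stated time of 72 h, at a dose of 3 mg/kg by the oral route (on this read-out lower numbers stand for lower oral bioavailability and higher numbers for higher oral bioavailability), compound 2 `CN1CC[C@H](N(c2cc(C#CC(C)(C)C)sc2C(=O)O)C(=O)[C@H]2CC[C@H](C)CC2)C1=O` gives (26%) and holds the lower of the two numbers known so far. Compound 1 `CN1CC[C@@H](N(c2cc(C#CC(C)(C)C)sc2C(=O)O)C(=O)[C@H]2CC[C@H](C)CC2)C1=O` gives (64%) on the same read-out. The measured step between them is large (a number 38 percentage points lower from compound 1 to compound 2 (beyond the scatter)) and can be traced to the fact that compounds 1 and 2 differ only in the configuration as drawn. Compound 3 `CN1CCCC[C@@H](N(c2cc(C#CC(C)(C)C)sc2C(=O)O)C(=O)[C@H]2CC[C@H](C)CC2)C1=O` brings a different kind of change: 1-methyl-2-oxoazepan-3-yl in place of 1-methyl-2-oxopyrrolidin-3-yl on an amide-type nitrogen. In words, 1-methyl-2-oxoazepan-3-yl stands in place of 1-methyl-2-oxopyrrolidin-3-yl on an amide-type nitrogen. Among the compounds with values here, no measured step covers such a change of ring size, so the single step available bears on it only indirectly. It does show that compounds sharing this core can lie far apart, which argues for a wide range. Compound 1 reaches (64%) while compound 2 sits low at (26%), so there is more known room upward than downward, and a moderate rise seems the likelier direction. The expected step is (a number 12 percentage points higher from compound 2 to compound 3 (beyond the scatter)) in this assay, though little certainty attaches to it. For compound 3 the estimated oral bioavailability is 38% (range 15% to 65%) .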

Compound 3, oral bioavailability: 122%
For compound 3 the middle estimate is 84 percentage points below the measured one; measured number above the stated range.
By their numbers in this assay, from the lowest: compound 2; then compound 1; then compound 3.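

In this assay, the swap of 1-methyl-2-oxopyrrolidin-3-yl for 1-methyl-2-oxoazepan-3-yl on the amide-type nitrogen gives a number 96 percentage points higher from compound 2 to compound 3 (beyond the scatter) and a number 58 percentage points higher from compound 1 to compound 3 (beyond the scatter), so compound 3 stands above both compounds with the five-membered ring. The earlier pair showed only that the drawn configuration matters at this position, whereas these steps show that the ring carrying that stereocentre can also be changed, and that the seven-membered ring is compatible with a high oral bioavailability. The same swap reads as two steps of different size because the two starting compounds are not identical: the fact that compounds 1 and 2 differ only in the configuration as drawn.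

What remains open is whether the number climbs steadily with ring size, since the six-membered 1-methyl-2-oxopiperidin-3-yl group lies outside the compounds shown, and so does the opposite configuration of the seven-membered ring. Nothing shown here explains why compound 3 rises so far, so the size of the ring can be tied to the change in the number but cannot be called its proven mechanism.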